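The source may report more compounds than this note shows. Statements on the series, on what has been measured and on what is new or still open speak of the compounds shown alone.

Compound 1 `Cc1ccc(S(=O)(=O)NN2C(=S)S/C(=C\c3ccc(Cl)c(Cl)c3)C2O)cc1`: > 100000 nM
Compound 2 `Cc1ccc(/C=C2\SC(=S)N(NS(=O)(=O)c3ccccc3)C2=O)cc1`: > 100000 nM
Compound 3 `COc1ccc(S(=O)(=O)NN2C(=S)S/C(=C\c3ccc(Cl)c(Cl)c3)C2O)cc1`: > 100000 nM

These three compounds were tested in a functional assay on HFF cells (Homo sapiens) for cytotoxicity (a higher number here means a weaker inhibitor, a lower number a stronger inhibitor), and every entry is a limit of the assay, not a number. Compound 3 stands at > 100000 nM, which is such a limit. It therefore has no exact value to start from, and the same is true of every result so far: the limit of > 100000 nM in this assay, at which 3 of the 3 values shown sit.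

The next compound, compound 4 `O=S(=O)(NN1C(=S)S/C(=C\c2ccc(Cl)c(Cl)c2)C1O)c1ccc(Cl)cc1`, has chloro in place of methoxy on an aromatic carbon, para to a large group: chloro in place of methoxy on an aromatic carbon. Put another way, a 4-methoxyphenyl becomes a 4-chlorophenyl, and the rest of the molecule stays the same.

Among the measured compounds shown here, one measured step bears on this change, at the same place on the molecule: a step that the two limits leave unreadable from compound 1 to compound 3, with methoxy in place of methyl. That step has no readable size, so it offers no measured effect to carry over. It does show that compound 1 and compound 3 both stayed at the limit with different groups at this place. No step beyond the usual scatter is therefore expected, and the expected change is a number no higher from compound 3 to compound 4 (the limit leaves the size open). Compound 4 will most likely be reported as a limit too. If a number is obtained, the estimate for compound 4 is 100000 nM, with an expected range from 40000 nM to 200000 nM.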

Compound 4, half-maximal inhibitory concentration: > 100000 nM
Compound 4 ended at the assay's limit; the forecaster's own chance of this, stated with the estimate: 85%; the middle value lies on the limit itself.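

Compound 4 gives a limit, not a number, in this assay, so its steps from compound 1 and from compound 3 cannot be read. All the results here stand at the same limit: the limit of > 100000 nM in this assay, at which 4 of the 4 values shown sit. The compounds shown leave open whether any group at this place would give a measurable value.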